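Cytotoxicity notes: fluorophenyl change on the amide side

A few compounds are considered here, and "the series" means these few. Any claim that something is new, unique, unknown or untested is made for them only; others in the source may bear on it.

Measured so far:
compound 1 `CC(C)Cc1nn(-c2cccc(F)c2)cc1C(=O)NCc1ccc(F)cc1` — > 100000 nM
compound 2 `CC(C)Cc1nn(-c2nccs2)cc1C(=O)NCc1ccc(F)cc1F` — 83600 nM

In a toxicity assay on HepG2 2.2.15 cells (Homo sapiens) for cytotoxicity, read by CCK-8 assay, with a stated time of 8 days (on this read-out lower numbers stand for higher toxicity in this test and higher numbers for lower toxicity in this test), compound 1 gives > 100000 nM, which is a limit of the assay and not a number. Compound 2 gives 83600 nM in this assay. Within the data shown here, compound 2 thus holds the only number in the set; the remaining value sits at the limit (the limit of > 100000 nM in this assay, at which 1 of the 2 values shown sits).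

Compound 3 `CC(C)Cc1nn(-c2nccs2)cc1C(=O)NCc1cccc(F)c1` differs from compound 2 in one place: 3-fluorophenyl in place of 2,4-difluorophenyl on a saturated chain carbon bound to an amide-type nitrogen. Among the measured compounds shown here, no measured step covers this change. Compound 1 also carries 3-fluorophenyl on that carbon, and in this assay compound 1 gives > 100000 nM, a limit. On that basis the step from compound 2 to compound 3 is expected to be small, if anything toward lower toxicity, and is expected to be a 1.1-fold higher number from compound 2 to compound 3 (0.06 log units; within the scatter), not beyond the scatter. Compound 3 is estimated at 95000 nM, with a range from 45000 nM to 200000 nM, and a fair chance that only a limit is returned.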

Compound 3, half-maximal cytotoxic concentration: > 100000 nM
Compound 3: no number, only a limit; the forecaster's own chance of this, stated with the estimate: 50%; at least 1.0-fold (0.02 log units) between middle value and limit.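

In this assay, 3-fluorophenyl in place of 2,4-difluorophenyl on a saturated chain carbon bound to an amide-type nitrogen gives an at least 1.1-fold higher number from compound 2 to compound 3 (0.07 log units; that floor lies within the scatter). Compound 3 gives > 100000 nM, which is a limit of the assay and not a number. This is the first reading of a change at this position: it gives no sign of higher toxicity in this test, but the true size of the step stays unfixed, and the set now offers little room for comparison: the limit of > 100000 nM in this assay, at which 2 of the 3 values shown sit.

The compounds shown leave open whether any group on this carbon brings the read-out well under the limit. A plain phenyl, a phenyl carrying a carboxylic acid or a phenyl carrying a primary amine would test this, as would a longer chain between the amide-type nitrogen and the ring.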